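A Longer Hydroxycarbamoyl Chain at the Assay Limit

The source may report more compounds than this note shows. Statements on the series, on what has been measured and on what is new or still open speak of the compounds shown alone.

In a functional assay on K562 cells (Homo sapiens) for antiproliferative activity, read by MTT assay, with a stated time of 48 h (on this read-out higher numbers stand for weaker inhibition and lower numbers for stronger inhibition), compound 1 (`O=C(CCCCCC(=O)Nc1nnc(-c2ccncc2)s1)NO`) gives > 60000 nM, which is a limit and not a number. Compound 2 (`O=C(CCCCCC(=O)Nc1nnc(-c2cccs2)s1)NO`) gives > 60000 nM, likewise a limit. Both values shown therefore stand at the same limit (the limit of > 60000 nM in this assay, at which 2 of the 2 values shown sit), so compound 1 has no measured potency to serve as a starting point.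

Compound 3 (`O=C(CCCCCCC(=O)Nc1nnc(-c2ccncc2)s1)NO`) differs from compound 1 at a single place: (hydroxycarbamoyl)methyl in place of hydroxycarbamoyl on a saturated chain carbon, five bonds along the chain from a carbonyl carbon. Here (hydroxycarbamoyl)methyl stands in place of hydroxycarbamoyl on a saturated chain carbon, five bonds along the chain from a carbonyl carbon.

Going by the values given here, only one measured step is available, a step that the two limits leave unreadable from compound 1 to compound 2, and it replaces pyridin-4-yl with thiophen-2-yl on an aromatic carbon, leaving the chain untouched. It offers no readable size and no direction for the chain change in this assay. Without such evidence, the expectation is that the new compound stays close to the limit, and a further limit is the likeliest report.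

The expected change is modest, as estimated by an at least 1.2-fold lower number from compound 1 to compound 3 (0.07 log units; that floor lies within the scatter). For compound 3, the estimated value is 50000 nM, with an expected range from 10000 nM to 120000 nM.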

Compound 3, half-maximal inhibitory concentration: 4150 nM
For compound 3 the middle estimate is 12-fold (1.08 log units) above the measured one; the whole stated range lies above it.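

In this assay, going by these compounds alone, putting (hydroxycarbamoyl)methyl in place of hydroxycarbamoyl on a saturated chain carbon, five bonds along the chain from a carbonyl carbon, gives the first step that can be read: an at least 14-fold lower number from compound 1 to compound 3 (1.16 log units; beyond the scatter). The earlier step, from pyridin-4-yl to thiophen-2-yl, cannot be read, so this chain position is the only place shown where a single change has a size and a direction, and here the number falls. Compound 3 is also the only compound shown with a measured value rather than a limit, and the other two compounds stay where they stood: the limit of > 60000 nM in this assay, at which 2 of the 3 values shown sit.

What the compounds shown leave open is whether the trend continues beyond this single step, as a longer chain such as 2-(hydroxycarbamoyl)ethyl or 3-(hydroxycarbamoyl)propyl would show, or reverses. They also leave open whether hydroxycarbamoyl itself is needed at the end of the chain, which a carboxylic acid there would test, and whether thiophen-2-yl in place of pyridin-4-yl can be read once it is carried on the chain of compound 3.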